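Azido for anilino on a nucleoside core: inhibition notes

The source may hold more compounds than are shown below. What is called first, only, known or untested is meant among the compounds shown, and "the series" means these compounds.

compound 1, `OC[C@H]1OC(n2cnc3c(Nc4ccccc4)nccc32)[C@H](O)[C@@H]1O`: 4%
compound 2, `[O-][n+]1ccc2[nH]cnc2c1`: 3%

In a functional assay (Homo sapiens) for inhibition of Nucleic Acid, tested at 100 uM (a lower number here means less inhibition, a higher number more inhibition at the concentration tested (going by the name of the read-out)), compound 1 gives 4% and compound 2 gives 3%. The two numbers lie within the usual scatter of each other, so neither stands apart. Compound 3, `[N-]=[N+]=Nc1nccc2c1ncn2C1O[C@H](CO)[C@@H](O)[C@H]1O`, is not yet measured. It differs from compound 1 in one place: azido in place of anilino on an aromatic carbon. The anilino group leaves and an azido group enters on an aromatic carbon of the core. Within the data shown here, no measured pair shows the effect of this change. Both measured values sit near the bottom of the scale, so the expected step of a number 1 percentage points higher from compound 1 to compound 3 (within the scatter) is none beyond the scatter. Compound 3 is expected to give 5%, estimated between -5% and 15%.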

Compound 3, a percentage reported as inhibition, at one concentration (the size of the read-out at that concentration, not a potency): 4%
Compound 3: the middle estimate sits 1 percentage points above what was measured; the measured number falls inside the stated range.
By their numbers in this assay, from the lowest: compounds 2, 1 and 3 (each within the scatter of the next).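

In this assay, azido in place of anilino on this aromatic carbon, next to the ring nitrogen, gives no change at the digits printed from compound 1 to compound 3 (within the scatter). At this position, then, the loss of the six-membered aromatic ring of carbon only and of the hydrogen-bond donor does not separate the two compounds, and the read-out stays near the bottom of the scale. No available evidence gives a reason for this result. The compounds shown leave open whether an amine or a methoxy group on this carbon would give a number beyond the scatter.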